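The compounds below may be only part of what the source reports. "The series", "measured", "known", "first", "only" and "open" are said of these compounds alone.

Compound 1 `CCOc1cccc(-c2ccc(CN(C(=O)C3CCCCC3)c3cccc(/C=C/C(=O)OC)c3)cc2)c1` and compound 2 `COC(=O)/C=C/c1cccc(N(Cc2ccc(-c3c(OC)cccc3OC)cc2)C(=O)C2CCCCC2)c1` share one core and differ only in the aryl group attached to it. In an assay on isolated protein with Bile acid receptor (Homo sapiens) as the target (on this read-out lower numbers stand for an effect already at smaller amounts and higher numbers for an effect only at larger amounts of compound), compound 1 gives 147 nM and compound 2 gives 77 nM. Among the measured compounds shown here, the one step between them, a 1.9-fold lower number from compound 1 to compound 2 (0.28 log units; within the scatter), leaves the two numbers within the usual scatter of each other, so compound 2 stands alongside compound 1 and no order between the two can be read from these numbers.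

Compound 3 `CCOC(=O)/C=C/c1ccc(CN(C(=O)C2CCCCC2)c2cccc(/C=C/C(=O)OC)c2)cc1` differs from compound 2 in that (2-(ethoxycarbonyl)ethenyl in place of 2,6-dimethoxyphenyl on an aromatic carbon). For the measured compounds named here, no measured step removes or replaces the aromatic ring at this position; the only step available, a 1.9-fold lower number from compound 1 to compound 2 (0.28 log units; within the scatter), exchanges one substituted phenyl for another and came out within the scatter, so it gives no direct guide to a change of this kind. With the aromatic ring gone and the 2-(ethoxycarbonyl)ethenyl group entering, a step beyond the scatter toward higher numbers in this assay is expected for compound 3, of about a 3.9-fold higher number from compound 2 to compound 3 (0.59 log units; beyond the scatter). The estimate for compound 3 in this assay is accordingly 300 nM, with a range from 80 nM to 1200 nM.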

Compound 3, half-maximal effective concentration: > 1000 nM
Compound 3 gave a limit, no number (the forecaster's own chance of this, stated with the estimate: 5%); middle value at least 3.3-fold (0.52 log units) away from the limit.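

In this assay the reading for compound 3 is a limit and not a number: the limit of > 1000 nM in this assay, at which 1 of the 3 values shown sits. The change reaches beyond the scatter from either aryl compound, as an at least 12-fold higher number from compound 2 to compound 3 (1.11 log units; beyond the scatter) and an at least 6.8-fold higher number from compound 1 to compound 3 (0.83 log units; beyond the scatter) show, with 2-(ethoxycarbonyl)ethenyl entering on an aromatic carbon para to a large group. Among the compounds shown here, the earlier exchange of one substituted phenyl for another showed only that these two aryl groups cannot be told apart at this position, whereas this result shows that the position does not accept every substituent alike, even though 2,6-dimethoxyphenyl and 2-(ethoxycarbonyl)ethenyl carry the same count of hydrogen-bond acceptors.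

The compounds shown do not separate the loss of the six-membered aromatic ring from the entry of the open chain with its ester, since both changes arrive together in compound 3. On these data alone, a cyclohexyl group or an unsubstituted phenyl at this place would address the ring alone, and a carboxylic acid in place of the ethoxycarbonyl end would address the ester, so how far each part counts remains open.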